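The source may hold more compounds than are shown below. What is called first, only, known or untested is meant among the compounds shown, and "the series" means these compounds.

Measured compounds:
Compound 1, `C[Se]/C(=N\C(=O)c1cc2ccccc2s1)NC(=O)c1cc2ccccc2s1`, gives 94000 nM.
Compound 2, `CS/C(=N\C(=O)c1ccno1)NC(=O)c1ccno1`, reaches only a limit of the assay, > 100000 nM.
Compound 3, `C[Se]/C(=N\C(=O)c1cnc2ccccc2c1)NC(=O)c1cnc2ccccc2c1`, likewise reaches only a limit of the assay, > 100000 nM.

All three were tested in a functional assay on PC-3 cells (Homo sapiens) for cytotoxicity, read by MTT assay, with a stated time of 72 h; a higher number here means that more compound is tolerated, a lower number that less compound is tolerated. For the measured compounds named here, compound 1 is the one compound with a number rather than a limit, and in this assay compound 1 gives 94000 nM. Going by the values given here, compound 3 stands at the limit itself, the point described by the limit of > 100000 nM in this assay, at which 2 of the 3 values shown sit; its reading tells only that the true value lies beyond that point, not where. Compound 2 sits at the same limit, so compound 1 and compound 3 cannot be placed in an order relative to each other.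

Compound 4, `O=C(/N=C(/NC(=O)c1cnc2ccccc2c1)[Se]Cc1ccccc1)c1cnc2ccccc2c1`, has not yet been measured. It differs from compound 3 in one place: phenyl in place of hydrogen on a saturated chain carbon bound to a selenium atom. Among the compounds with values here, no pair of measured compounds differs in a comparable way, so there is no measured step to lean on. The expectation for the change from compound 3 to compound 4 is therefore a step of a number no higher from compound 3 to compound 4 (the limit leaves the size open), meaning none beyond the usual scatter, with the reading for compound 4 expected to remain at or near the limit. For compound 4 in this assay the estimate is 100000 nM, with a range from 40000 nM to 250000 nM.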

Compound 4, concentration lethal to 50% of the cells: > 100000 nM
Compound 4: a limit, no number (the forecaster's own chance of this, stated with the estimate: 60%); the middle value lies on the limit itself.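

Compound 3 and compound 4 each give only a limit rather than a number, so no step can be read between them: the limit of > 100000 nM in this assay, at which 3 of the 4 values shown sit. The compounds shown leave open where the true values of compound 3 and compound 4 lie, and so whether phenyl in place of hydrogen changes the reading at all.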